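The source may report more compounds than this note shows. Statements on the series, on what has been measured and on what is new or still open speak of the compounds shown alone.

Of the compounds shown here, three on one shared core have been tested in a functional assay on cells (Macrophage, Homo sapiens) for cytotoxicity; on this read-out lower numbers stand for higher toxicity in this test and higher numbers for lower toxicity in this test: compound 1 (`CNNC(=O)c1[nH]c2ccc(Cl)cc2c1S(=O)(=O)c1cc(C)cc(C)c1`), compound 2 (`Cc1cc(C)cc(S(=O)(=O)c2c(C(=O)NNC(C)C)[nH]c3ccc(Cl)cc23)c1`) and compound 3 (`Cc1cc(C)cc(S(=O)(=O)c2c(C(=O)NNC3CCCCC3)[nH]c3ccc(Cl)cc23)c1`). Compound 1 gives > 100 uM, which is a limit of the assay and not a number. Compound 2 gives > 100 uM, again a limit. Compound 3 gives > 100 uM, also a limit, so its place in the series is not fixed by a number.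

Compound 4 (`CC(=O)NNC(=O)c1[nH]c2ccc(Cl)cc2c1S(=O)(=O)c1cc(C)cc(C)c1`) carries acetyl in place of cyclohexyl on an amine nitrogen. Three measured steps change the group at this place, and none has a readable size: a step that the two limits leave unreadable from compound 1 to compound 2; a step that the two limits leave unreadable from compound 1 to compound 3; a step that the two limits leave unreadable from compound 2 to compound 3. For the measured compounds named here, the only guide is the limit of > 100 uM in this assay, at which 3 of the 3 values shown sit, and it suggests that compound 4 will probably remain at the limit, although acetyl has not been tested here. The expected change in this assay is therefore nothing beyond the scatter: a number no higher from compound 3 to compound 4 (the limit leaves the size open). For compound 4 the estimated value is 100 uM, with an expected range from 40 uM to 200 uM.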

Compound 4, half-maximal toxic concentration: > 100 uM
Compound 4: only a limit was reported; the forecaster's own chance of this, stated with the estimate: 80%; the middle value sits exactly at the limit.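

Compound 4, like compound 1, compound 2 and compound 3, stands only at a limit in this assay, so no step among these compounds can be read. The compounds shown leave open whether any group on this amine nitrogen changes the toxic concentration, since all remain at one value: the limit of > 100 uM in this assay, at which 4 of the 4 values shown sit.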